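Swapping Iodo for Methyl on an Aromatic Ring

The compounds below may be only part of what the source reports. "The series", "measured", "known", "first", "only" and "open" are said of these compounds alone.

Of the compounds shown here, three have been tested so far, and their numbers sit close together. In a functional assay on A549 cells (Homo sapiens) for cytotoxicity, read by MTT assay, with a stated time of 48 h (on this read-out higher numbers stand for weaker inhibition and lower numbers for stronger inhibition), compound 1 `C=C1CCC[C@]2(C)CCC(C=O)=CC[C@@]12C` gives 145000 nM. Compound 2 `C#CC1=CC[C@]2(CC1)C(=C)CC[C@H]2C(C)C` gives 103000 nM, and it is built on a different core from the other compounds here. Compound 3 `C=C1CCC[C@]2(C)CCC(c3cn(-c4ccc(I)cc4)nn3)=CC[C@@]12C` gives 137000 nM. It keeps the core of compound 1 and carries a 4-iodophenyl group. Its value lies within the usual scatter of repeat measurements from both compound 1 and compound 2, so these three numbers cannot be put in a meaningful order.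

Compound 4 `C=C1CCC[C@]2(C)CCC(c3cn(-c4ccc(C)cc4)nn3)=CC[C@@]12C` has not been measured yet. It differs from compound 3 in a single place: methyl in place of iodo on an aromatic carbon. In words, this is methyl in place of iodo on an aromatic carbon, so 4-iodophenyl becomes 4-methylphenyl.

Compound 1 at 145000 nM and compound 3 at 137000 nM carry quite different groups on the shared core, yet their values fall within the scatter of each other. On that basis, no step beyond the scatter is expected in this assay for this smaller swap. The estimated step of a 1.1-fold lower number from compound 3 to compound 4 (0.04 log units; within the scatter) is therefore small, with no firm direction. For compound 4 the estimated value is 125000 nM, with an expected range from 70000 nM to 200000 nM.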

Compound 4, half-maximal inhibitory concentration: 58800 nM
Estimate against measurement, compound 4: 2.1-fold (0.33 log units) above; the measured number lies below the stated range.
By their numbers in this assay, from the lowest: compounds 4, 2, 3 and 1 (each within the scatter of the next, the first and the last beyond it).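

In this assay, the swap of iodo for methyl gives a 2.3-fold lower number from compound 3 to compound 4 (0.37 log units; beyond the scatter), a modest step but the first one here that clears the scatter. The earlier numbers sat too close together to show whether anything on this core mattered, whereas this pair shows that the group on this aromatic carbon, para to a large group, can shift the result, and that the shift is towards stronger inhibition. The change is also very small on paper: one heavy atom leaves and one enters, with no ring, hydrogen-bond donor, hydrogen-bond acceptor or net charge involved on either side, and nothing available here explains the step.

As far as these compounds go, it remains open whether the step comes from losing iodo or from gaining methyl, and an unsubstituted phenyl ring, or chloro, methoxy or ethyl at the same place, would help to separate the two. Also open, from the compounds shown here alone, is whether the lower number is specific to these cells, since every value here comes from a single cell line.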